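This account rests on a few compounds, and the source may have more. Where it says the series, first, only, none or still open, it means among the compounds named here.

Three compounds set the stage. Compound 1, `Cc1cccc(C(=O)NCN2CCC(c3ccccn3)CC2)c1`, was tested in a functional assay on HEK293 cells for agonist activity at D(4) dopamine receptor (Homo sapiens), read by FLIPR (a higher number here means a larger maximal response, a lower number a smaller maximal response), where compound 1 gives 67%. Compound 2, `Cc1cccc(NC(=O)CN2CCC(c3nccs3)CC2)c1`, gives 62% in this assay, and compound 3, `Oc1ccc(N2CCN(Cc3nc4ccccc4[nH]3)CC2)nc1`, gives 70%. The three numbers sit close together: the reading for compound 1 differs from that of compound 3 and from that of compound 2 by amounts that fall within the usual scatter of repeated measurements, so no one of the three can be called larger or smaller than another on this evidence.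

The step to follow leads from compound 1 to a compound not yet measured, compound 4, `COc1ccccc1C1CCN(CNC(=O)c2cccc(C)c2)CC1`. The structural change is 2-methoxyphenyl in place of pyridin-2-yl on a saturated ring carbon. Among the measured compounds shown here, no pair of measured compounds differs by this kind of swap, so there is no measured step to borrow from. In the absence of such a step, the expectation for compound 4 in this assay is a change of roughly a number 2 percentage points lower from compound 1 to compound 4 (within the scatter), that is, nothing clearly beyond the scatter. The estimated maximal response for compound 4 is therefore 65%, in a range from 45% to 85%.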

Compound 4, largest response reached (reported as efficacy), in percent of the reference or control that the assay uses: 55%
Beside the measured number, compound 4's estimate is 10 percentage points above it, and the stated range covers the measured number.
By their numbers in this assay, from the lowest: compounds 4, 2, 1 and 3 (each within the scatter of the next, the first and the last beyond it).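

Among the compounds shown here, this position on the saturated ring carbon, three ring bonds from the ring nitrogen, now gives the first readable step in this assay, since pyridin-2-yl giving way to 2-methoxyphenyl brings a number 12 percentage points lower from compound 1 to compound 4 (beyond the scatter), a modest change. The two groups have the same counts of hydrogen-bond donors and acceptors and no net charge, so those counts do not separate them, and the swap alters two things at once: the ring loses its nitrogen and gains a methoxy group. No measurement here explains the drop.

From the compounds shown here alone, it remains open whether a plain phenyl group at this place would read like compound 1 or like compound 4, which would show which part of the swap carries the step. Going by these compounds, how an ethoxy or a hydroxy group would read in place of the methoxy group also remains open.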